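A few compounds are considered here, and "the series" means these few. Any claim that something is new, unique, unknown or untested is made for them only; others in the source may bear on it.

Three compounds have been measured in an assay on isolated protein for inhibition of DNA topoisomerase 1 (Homo sapiens), with a stated time of 15 min; a lower number here means a stronger inhibitor, a higher number a weaker inhibitor:

Compound 1, `CNCCCNc1c(F)cc2c(=O)c(C(=O)O)cn(Cc3ccc(-c4ccccc4)cc3)c2c1OC`, gives 101000 nM.
Compound 2, `CNC(=O)c1cn(Cc2ccc(-c3ccccc3)cc2)c2c(OC)c(N3CC[C@@H](CN)C3)c(F)cc2c1=O`, gives 82100 nM.
Compound 3, `COc1c(N2CC[C@@H](N)C2)c(F)cc2c(=O)c(C(=O)O)cn(Cc3ccc(-c4ccccc4)cc3)c12`, gives 92200 nM.

All three numbers are weak and lie within the usual scatter of one another, so none of them can be ranked against the others. Among the measured compounds shown here, compound 3 sits inside this narrow band; the one step that reaches it, a 1.1-fold lower number from compound 1 to compound 3 (0.04 log units; within the scatter), replaced the whole side chain on the aromatic carbon and still left the number where it was.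

Compound 4, `CNC[C@@H]1CCN(c2c(F)cc3c(=O)c(C(=O)O)cn(Cc4ccc(-c5ccccc5)cc4)c3c2OC)C1`, has not yet been measured. It differs from compound 3 in one place: (methylamino)methyl in place of amino on a saturated ring carbon. For the measured compounds named here, the only measured step that touches this region of the molecule is a 1.1-fold lower number from compound 1 to compound 3 (0.04 log units; within the scatter). It does not test the same change: it swapped one side chain for another rather than lengthening a group on the saturated ring, so it gives only loose guidance. Nothing among the three measured compounds points to a step beyond the scatter in either direction in this assay. Compound 4 is therefore expected to land close to compound 3, an estimated step of a 1.0-fold lower number from compound 3 to compound 4 (0.01 log units; within the scatter). The estimate for compound 4 in this assay is 90000 nM, with a likely range from 40000 nM to 200000 nM.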

Compound 4, half-maximal inhibitory concentration: 155000 nM
The estimate for compound 4 lay 1.7-fold (0.24 log units) below the measured number; the measured number falls inside the stated range.
By their numbers in this assay, from the lowest: compounds 2, 3, 1 and 4 (each within the scatter of the next).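

In this assay, the only direct test of this ring carbon gives a 1.7-fold higher number from compound 3 to compound 4 (0.23 log units; within the scatter) when (methylamino)methyl, with 3 heavy atoms, takes the place of amino, with 1 heavy atom. Adding these atoms to the saturated ring therefore produces no step beyond the scatter, and the same holds for the larger exchange on the aromatic carbon, where 3-((methylamino)methyl)pyrrolidin-1-yl in place of (3-(methylamino)propyl)amino gives a 1.5-fold higher number from compound 1 to compound 4 (0.19 log units; within the scatter) and leaves compounds 1, 3 and 4 all within the scatter of one another. No measurement here explains why these numbers stay so close together, so no cause can be given.

As far as these compounds go, all the groups compared on this saturated ring carbon are amines, so it remains open whether a hydroxyl, a fluorine or a longer chain such as (ethylamino)ethyl there would move the number beyond the scatter. From the compounds shown here alone, it is also open whether any group at this position can bring the number far below the weak band seen so far, or whether the shared core sets that band whatever the ring carries.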